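A few compounds are considered here, and "the series" means these few. Any claim that something is new, unique, unknown or untested is made for them only; others in the source may bear on it.

Measured in a functional assay on MCF7 cells (Homo sapiens) for cytotoxicity, read by CellTiter-Glo, with a stated time of 5 days; a lower number here means a stronger inhibitor, a higher number a weaker inhibitor
- Compound 1 `CC/C(=C(/c1ccc(/C=C/C(=O)O)cc1)c1ccc2[nH]ncc2c1)c1ccccc1` gives 6 nM
- Compound 2 `CC/C(=C(/c1ccc(/C=C/C(=O)O)cc1)c1ccc2[nH]ncc2c1)c1ccccc1C#N` gives 12 nM
- Compound 3 `CC/C(=C(/c1ccc(/C=C/C(=O)O)cc1)c1ccc2[nH]ncc2c1)c1cccc(C#N)c1` gives 100 nM

Compound 3 holds the highest number of the three, beyond the scatter from both others. The move to compound 4 `CC/C(=C(/c1ccc(/C=C/C(=O)O)cc1)c1ccc2[nH]ncc2c1)c1ccccc1S(C)(=O)=O` is 2-(methylsulfonyl)phenyl in place of 3-cyanophenyl on a double-bonded chain carbon bound to a double-bonded chain carbon and a saturated chain carbon and puts 2-(methylsulfonyl)phenyl in place of 3-cyanophenyl. For the measured compounds named here, the steps that bear on it are a 17-fold higher number from compound 1 to compound 3 (1.22 log units; beyond the scatter) and an 8.3-fold higher number from compound 2 to compound 3 (0.92 log units; beyond the scatter), both ending at compound 3, while a 2.0-fold higher number from compound 1 to compound 2 (0.30 log units; within the scatter) stays within the scatter. Going by the values given here, the entering group is substituted as in compound 2, but no sulfonyl compound has yet been measured. In this assay the expected change is a 4.0-fold lower number from compound 3 to compound 4 (0.60 log units; beyond the scatter) and so a move to a lower number. Compound 4 is estimated at 25 nM with an expected range from 8 nM to 80 nM in this series.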

Compound 4, half-maximal inhibitory concentration: 70 nM
Beside the measured number, compound 4's estimate is 2.8-fold (0.45 log units) below it, and the stated range covers the measured number.
By their numbers in this assay, from the lowest: compounds 1 and 2 (each within the scatter of the next); then compounds 4 and 3 (each within the scatter of the next).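

In this assay, 2-(methylsulfonyl)phenyl in place of 3-cyanophenyl gives (a 1.4-fold lower number from compound 3 to compound 4 (0.15 log units; within the scatter)), so these two groups are not separated at this double-bonded chain carbon. On the same ring, methylsulfonyl in place of cyano gives (a 5.8-fold higher number from compound 2 to compound 4 (0.77 log units; beyond the scatter)) and methylsulfonyl in place of hydrogen gives (a 12-fold higher number from compound 1 to compound 4 (1.07 log units; beyond the scatter)), so the identity of the group matters here, not its place on the ring alone. No measurement bears on the cause of these steps.

Still open, from the compounds shown here alone, is whether 3-(methylsulfonyl)phenyl would follow 2-(methylsulfonyl)phenyl. Also open, going by these compounds, is how a methoxy group or an amine on the ring would compare.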